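Fluoro in place of nitro on the anilino ring of compound 2

This account rests on a few compounds, and the source may have more. Where it says the series, first, only, none or still open, it means among the compounds named here.

Of the compounds shown here, two have been measured in a functional assay on CCRF-CEM cells (Homo sapiens) for cytotoxicity, in the absence of a further agent; a lower number here means a stronger inhibitor, a higher number a weaker inhibitor. For the measured compounds named here, compound 1 `COC(=O)c1ccc(CN(CCCc2c(N)nc(N)nc2O)c2cc(F)cc(F)c2[N+](=O)[O-])cc1` carries a methyl ester in place of the glutamate diester and differs from compound 2 in more than one place, so it yields no single step. In this assay compound 1 gives > 100000 nM, which is a limit of the assay and not a number. Going by the values given here, the only numeric value shown belongs to compound 2 `CC(C)(C)OC(=O)CCC(Nc1ccc(CN(CCCc2c(N)nc(N)nc2O)c2ccc([N+](=O)[O-])c(F)c2[N+](=O)[O-])cc1)C(=O)OC(C)(C)C`, which in this assay gives 3900 nM; the other value shown is the limit of > 100000 nM in this assay, at which 1 of the 2 values shown sits. Among the compounds with values here, no step between measured compounds that differ in one place is available, so nothing in the data sets the scale for the change that follows.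

Compound 3 `CC(C)(C)OC(=O)CCC(Nc1ccc(CN(CCCc2c(N)nc(N)nc2O)c2ccc([N+](=O)[O-])c(F)c2F)cc1)C(=O)OC(C)(C)C` is not yet measured. It differs from compound 2 by fluoro in place of nitro on an aromatic carbon. Without a measured single-place step, the size of this change can only be expected: the step from compound 2 to compound 3 is expected to be a 1.5-fold higher number from compound 2 to compound 3 (0.19 log units; within the scatter), toward a somewhat weaker inhibitor, at most modestly beyond the scatter. For compound 3 the estimate in this assay is 6000 nM, with a range from 1500 nM to 25000 nM.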

Compound 3, half-maximal inhibitory concentration: 20000 nM
The estimate for compound 3 lay 3.3-fold (0.52 log units) below the measured number; the measured number falls inside the stated range.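

For the compounds shown here, the first measured single-place step falls at this position: on a carbon ortho to a fluoro group and meta to a nitro group, the exchange of nitro for fluoro gives a 5.1-fold higher number from compound 2 to compound 3 (0.71 log units; beyond the scatter) in this assay. Going by these compounds alone, the position is therefore not indifferent to this exchange, and the size of the step now gives the series a first scale for changes on the anilino ring, while compound 3 still gives a number, so the step can be read in full. The only limit in the set belongs to compound 1, and it is a limit of the assay and not a number: the limit of > 100000 nM in this assay, at which 1 of the 3 values shown sits.

One exchange at one position cannot show whether the higher number follows from the loss of the nitro group as such or is specific to fluoro, and an amine or a nitrile on the same carbon would separate those two readings. Also open, as far as these compounds go, is whether the same exchange at the remaining nitro group gives a step of similar size, and whether this step holds when the glutamate diester gives way to a free carboxylic acid.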